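Swapping a Methoxyphenyl Ketone for a Dichlorophenyl Ketone

A few compounds are considered here, and "the series" means these few. Any claim that something is new, unique, unknown or untested is made for them only; others in the source may bear on it.

Compound 1 `COC(=O)c1cc(-c2cccc(NC(=O)c3ccc(/C=C/C(=O)c4ccc(Cl)cc4)cc3)c2)on1` and compound 2 `COC(=O)c1cc(-c2cccc(NC(=O)c3ccc(/C=C/C(=O)c4cccc(OC)c4)cc3)c2)on1` share one core and differ only in the aryl group attached to a carbonyl carbon. In an ADME assay on Vero cells (Chlorocebus sabaeus) for cytotoxicity, read by MTT assay, with a stated time of 72 h (on this read-out lower numbers stand for higher toxicity in this test and higher numbers for lower toxicity in this test), compound 1 gives > 50 ug/mL, which is a limit of the measurement and not a number. In this assay compound 2 gives > 100 ug/mL, again a limit rather than a number. The step that the two limits leave unreadable from compound 1 to compound 2 therefore cannot be read, since both ends sit at limits, namely the limit of > 100 ug/mL in this assay, at which 1 of the 2 values shown sits, and (the limit of > 50 ug/mL in this assay, at which 1 of the 2 values shown sits).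

Compound 3 `COC(=O)c1cc(-c2cccc(NC(=O)c3ccc(/C=C/C(=O)c4ccc(Cl)cc4Cl)cc3)c2)on1` carries the change (2,4-dichlorophenyl in place of 3-methoxyphenyl on a carbonyl carbon). Among the compounds with values here, the only measured step that bears on this position is the one from compound 1 to compound 2, and its size is not readable. No direction of change can be derived from it. The expected step of an at least 1.2-fold lower number from compound 2 to compound 3 (0.09 log units; that floor lies within the scatter) is therefore none beyond the usual scatter. Compound 3 is estimated to give 80 ug/mL in this assay, with a range from 30 ug/mL to 150 ug/mL, most likely reported as a limit again.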

Compound 3, half-maximal cytotoxic concentration: > 40 ug/mL
Compound 3 ended at the assay's limit; the forecaster's own chance of this, stated with the estimate: 70%; the middle value lies beyond the limit too.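

In this assay compound 3 gives > 40 ug/mL, which is a limit and not a number. With compound 1 and compound 2 also at limits, no step among these three compounds can be read. From the compounds shown here alone, whether the aryl group on the carbonyl carbon changes the toxicity in this test, and by how much, remains open.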